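Removing the chloro group from compound 2

This account rests on a few compounds, and the source may have more. Where it says the series, first, only, none or still open, it means among the compounds named here.

Compound 2 `N=C(N)c1ccc(-c2ccc(-c3ccc(Cl)cc3)o2)o1` gives 1790 nM in a functional assay on SK-OV-3 cells (Homo sapiens) for inhibition, read by sulforhodamine B assay, with a stated time of 48 h (a higher number here means a weaker inhibitor of growth, a lower number a stronger inhibitor of growth), the lowest of the three numbers in hand. Compound 1 `COc1ccc(-c2ccc(-c3ccc(C(=N)N)o3)o2)cc1` gives 5630 nM in this assay, and compound 3 `COc1cc(OC)cc(-c2ccc(-c3ccc(C(=N)N)o3)o2)c1` gives 14900 nM. Compound 2 thus stands apart from both of the others, beyond the scatter in each case, with the gap to compound 3 the larger one.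

Compound 4 `N=C(N)c1ccc(-c2ccc(-c3ccccc3)o2)o1` differs from compound 2 by hydrogen in place of chloro on an aromatic carbon.

Among the compounds with values here, the one measured step that touches the same site is a 3.1-fold lower number from compound 1 to compound 2 (0.50 log units; beyond the scatter). It shows that changing the group at this position shifts the number by a modest amount. Within the data shown here, compound 3 carries two methoxy groups on the same ring and sits higher still, but no single-point step between it and compound 2 is computed. Nothing in hand compares chloro with hydrogen directly, so the size of the step to compound 4 is uncertain; since the chloro compound is the lowest of the three, removing the chloro seems unlikely to lower the number further, and a modest rise is the more plausible outcome.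

Compound 4 is therefore expected to give about 3500 nM in this assay, within 1500 nM to 8000 nM. The expected step of a 2.0-fold higher number from compound 2 to compound 4 (0.29 log units; within the scatter) is estimated to be modest and may not exceed the scatter.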

Compound 4, concentration for 50% growth inhibition: 4300 nM
Beside the measured number, compound 4's estimate is 1.2-fold (0.09 log units) below it; low and high end bracket the measured number.
By their numbers in this assay, from the lowest: compound 2; then compounds 4 and 1 (each within the scatter of the next); then compound 3.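

The direct comparison of chloro with hydrogen at this place, on an aromatic carbon para to a large group, gives a 2.4-fold higher number from compound 2 to compound 4 (0.38 log units; beyond the scatter) in this assay, so the chloro group of compound 2 accounts for a modest step of its own. Methoxy, by contrast, cannot be told apart from hydrogen here, with a 1.3-fold lower number from compound 1 to compound 4 (0.12 log units; within the scatter), which means that the earlier 3.1-fold lower number from compound 1 to compound 2 (0.50 log units; beyond the scatter) reflects chloro standing apart from both other groups, not methoxy raising the number relative to hydrogen. Nothing in hand gives a reason why chloro separates from hydrogen and methoxy at this place.

As far as these compounds go, whether a bromo or fluoro group, an amine or a carboxylic acid at this place would fall level with chloro, go beyond it or stay with hydrogen and methoxy remains open. Also open, from the compounds shown here alone, is whether the step from chloro to hydrogen would keep its size on a ring carrying more than one group, as the ring with two methoxy groups in compound 3 does.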